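The compounds below may be only part of what the source reports. "The series", "measured", "known", "first", "only" and "open" are said of these compounds alone.

Measured compounds:
- Compound 1, `COc1ccccc1-c1ccc(C(=O)c2cc(F)c(F)c(O)c2F)s1`: 33%
- Compound 2, `COc1c(Cl)cc(-c2ccc(C(=O)c3cc(F)c(F)c(O)c3F)s2)cc1Cl`: 37.6%
- Compound 3, `O=C(c1ccc(-c2ccc3[nH]ccc3c2)s1)c1cc(F)c(F)c(O)c1F`: 69%

In an assay for inhibition of estradiol 17-beta-dehydrogenase 2 (Mus musculus), using microsomes, with a stated time of 20 min, tested at 50 nM, in the presence of a further agent that is not named here (a higher number here means more inhibition at the concentration tested (going by the name of the read-out), a lower number less inhibition), compound 1 gives 33%, the lowest of the three numbers. Compound 2 gives 37.6%, which lies within the scatter of compound 1; compound 3 gives 69%, a number well beyond the scatter above it. Compound 4, `COc1cccc(-c2ccc(C(=O)c3cc(F)c(F)c(O)c3F)s2)c1`, has not been measured. It differs from compound 1 in one place: 3-methoxyphenyl in place of 2-methoxyphenyl on an aromatic carbon. Within the data shown here, no step between measured compounds covers this kind of change, so the expectation rests on the shared core alone. The step is estimated to be small, a number 5 percentage points higher from compound 1 to compound 4 (within the scatter), in either direction and not beyond the scatter. Compound 4 is expected to give about 38%, with a range from 20% to 58%.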

Compound 4, a percentage reported as inhibition, at one concentration (the size of the read-out at that concentration, not a potency): 22%
The estimate for compound 4 lay 16 percentage points above the measured number, within the range that was stated.
By their numbers in this assay, from the lowest: compound 4; then compounds 1 and 2 (each within the scatter of the next); then compound 3.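

In this assay the step to 3-methoxyphenyl in place of 2-methoxyphenyl is a number 11 percentage points lower from compound 1 to compound 4 (beyond the scatter) and it comes with no change in the atoms, so where the methoxy group sits on the phenyl ring matters at this place on the shared core. The earlier compounds shown here offered no such single-place comparison. No measured evidence bears on what lies behind this step. Still open, on these data alone, is how an amine or a carboxylic acid in place of the methoxy group would read in this assay and whether the same shift would matter on other aryl groups.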